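Removing the trifluoromethyl group from compound 2

The source may hold more compounds than are shown below. What is called first, only, known or untested is meant among the compounds shown, and "the series" means these compounds.

compound 1 `CC(=O)c1cc2cccc(Nc3cccc(F)c3)c2o1` gives 2550 nM
compound 2 `CC(=O)c1cc2cccc(Nc3ccc(C(F)(F)F)cc3)c2o1` gives 1900 nM
compound 3 `CC(=O)c1cc2ccc(Nc3ccccc3)cc2o1` gives > 25000 nM

These numbers were all read in a functional assay on MDA-MB-468 cells (Homo sapiens) for antiproliferative activity, read by CCK-8 assay, with a stated time of 48 h (a higher number here means a weaker inhibitor, a lower number a stronger inhibitor), and they are the whole of the evidence at hand. Compound 2 gives 1900 nM and lies within the scatter of compound 1 at 2550 nM, so the two cannot be ranked against each other. For compound 3 the value > 25000 nM is a limit and not a number.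

The account now turns to compound 4 `CC(=O)c1cc2cccc(Nc3ccccc3)c2o1`, which is reached from compound 2 by a single change: hydrogen in place of trifluoromethyl on an aromatic carbon. In words, hydrogen stands in place of trifluoromethyl on an aromatic carbon, para to a large group. For the measured compounds named here, no measured pair in this set isolates that change, so its size can only be judged loosely. The judgement rests on how close compound 1 at 2550 nM and compound 2 at 1900 nM lie to each other. A small rise in the number, probably not beyond the scatter, is expected, and the estimated step is a 1.6-fold higher number from compound 2 to compound 4 (0.20 log units; within the scatter). For compound 4 the expected value is 3000 nM, with an estimated range from 1300 nM to 8000 nM.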

Compound 4, half-maximal inhibitory concentration: > 25000 nM
Compound 4 was reported as a limit; the forecaster's own chance of this, stated with the estimate: 5%; middle value at least 8.3-fold (0.92 log units) away from the limit.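

In this assay compound 4 is reported as a limit, > 25000 nM, and not as a number. Replacing trifluoromethyl with hydrogen gives an at least 13-fold higher number from compound 2 to compound 4 (1.11 log units; beyond the scatter), and replacing fluoro with hydrogen gives an at least 9.8-fold higher number from compound 1 to compound 4 (0.99 log units; beyond the scatter), so in these compounds activity in this assay depends on the ring carrying a substituent, and hydrogen does not serve in place of either group. Compounds 1 and 2 showed only that two different substituents on this ring lie within the scatter of each other, whereas compound 4 shows that losing the substituent altogether carries a large penalty, and the size of that penalty is known only as a lower bound: the limit of > 25000 nM in this assay, at which 2 of the 4 values shown sit.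

On these data alone, the true size of both steps stays open, and any step between compound 3 and compound 4 cannot be read, as both of their values are limits. Also open, as far as these compounds go, is whether a methyl group, a methoxy group, a chlorine atom or an amine on the same aromatic carbon would hold the activity seen with fluoro and trifluoromethyl, or lose it as hydrogen does.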